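A few compounds are considered here, and "the series" means these few. Any claim that something is new, unique, unknown or untested is made for them only; others in the source may bear on it.

Four compounds share one core and differ at two places. Compound 1 `CC(C)CCn1nc(-c2cccs2)c(O)c(C2=NS(=O)(=O)c3cc(N(C)S(C)(=O)=O)ccc3N2)c1=O` carries methyl(methylsulfonyl)amino on an aromatic carbon, and in an in vitro ADME assay on microsomes from liver (Homo sapiens) for metabolic stability, tested at 5 uM (on this read-out higher numbers stand for a longer-lived compound and lower numbers for a shorter-lived compound), compound 1 gives 0.467 h. Among the measured compounds shown here, compound 2 `CC(C)CCn1nc(-c2cccs2)c(O)c(C2=NS(=O)(=O)c3cc(S(=O)(=O)N(C)C)ccc3N2)c1=O` carries dimethylsulfamoyl instead, and in this assay compound 2 gives 0.183 h; that change is the only measured step, a 2.6-fold lower number from compound 1 to compound 2 (0.41 log units; beyond the scatter). Compound 3 `CS(=O)(=O)Nc1ccc2c(c1)S(=O)(=O)N=C(c1c(O)c(-c3cccs3)nn(CC3CCC3)c1=O)N2` carries cyclobutylmethyl on the aromatic nitrogen. In this assay compound 3 reaches a limit of the assay, > 1 h, which is not a number but the edge of what the assay reports, as the limit of > 1 h in this assay, at which 1 of the 3 values shown sits, shows. Compound 4 `CS(=O)(=O)Nc1ccc2c(c1)S(=O)(=O)N=C(c1c(O)c(-c3cccs3)nn(Cc3ccccn3)c1=O)N2` differs from compound 3 in one place: pyridin-2-yl in place of cyclobutyl on a saturated chain carbon bound to an aromatic nitrogen. For the measured compounds named here, no measured step touches this position; the single measured step, from compound 1 to compound 2, concerns a different part of the molecule and gives no guide to the size or direction of the change here. With compound 3 sitting at a limit rather than at a number, any estimate for the step must be loose. Compound 4 is expected to give 0.9 h, within a range from 0.4 h to 1.8 h. The expected step is an at least 1.1-fold lower number from compound 3 to compound 4 (0.04 log units; that floor lies within the scatter), meaning no clear shift beyond the scatter is anticipated.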

Compound 4, half-life: > 1 h
Compound 4: no number, only a limit (the forecaster's own chance of this, stated with the estimate: 45%); middle value at least 1.1-fold (0.04 log units) from the limit.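

In this assay compound 4 gives > 1 h, which is a limit of the assay and not a number. Compound 3 stands at the same kind of limit, so no step between compound 3 and compound 4 can be read: the limit of > 1 h in this assay, at which 2 of the 4 values shown sit.

The compounds shown leave open whether (pyridin-2-yl)methyl in place of cyclobutylmethyl changes the half-life at all.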